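A few compounds are considered here, and "the series" means these few. Any claim that something is new, unique, unknown or untested is made for them only; others in the source may bear on it.

Compound 1 `Oc1ccccc1-c1cc(-c2cccc(F)c2)cc(-c2ccccc2O)n1` and compound 2 `Oc1cccc(-c2cc(-c3cccc(F)c3)cc(-c3ccccc3O)n2)c1` share one core. In a functional assay on T47D cells (Homo sapiens) for inhibition (on this read-out lower numbers stand for stronger inhibition and higher numbers for weaker inhibition), compound 1 gives only a limit, > 50000 nM. Compound 2 likewise gives only a limit in this assay, > 50000 nM. The change between them is 3-hydroxyphenyl in place of 2-hydroxyphenyl on an aromatic carbon, and the step that the two limits leave unreadable from compound 1 to compound 2 stays unreadable because of the limit of > 50000 nM in this assay, at which 2 of the 3 values shown sit. Compound 3 `Oc1ccccc1-c1cc(-c2ccccc2OC(F)(F)F)cc(-c2ccccc2O)n1` differs from compound 1 in more than one place; the difference between the two cores is not broken down here. In this assay compound 3 gives 1730 nM. Compound 4 `Oc1cccc(-c2cc(-c3ccccc3OC(F)(F)F)cc(-c3ccccc3O)n2)c1` carries the same kind of change, (3-hydroxyphenyl in place of 2-hydroxyphenyl on an aromatic carbon), the place now being meta to a large group rather than meta to a 3-fluorophenyl group. With the earlier step unreadable, compound 4 is expected to weaken by a 4.6-fold higher number from compound 3 to compound 4 (0.67 log units; beyond the scatter). That expectation rests on compound 3 alone, whose 1730 nM is the only number shown. The estimate for compound 4 is 8000 nM, between 2000 nM and 50000 nM.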

Compound 4, half-maximal inhibitory concentration: 2680 nM
Compound 4: middle estimate off by 3.0-fold (0.47 log units), on the high side, within the range that was stated.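

In this assay, the swap of 2-hydroxyphenyl for 3-hydroxyphenyl on the core of compound 3 gives a 1.5-fold higher number from compound 3 to compound 4 (0.19 log units; within the scatter), so the two values cannot be told apart on this core. The same swap on the core of compound 1 cannot be read, because compound 1 and compound 2 each give only a limit of the assay: the limit of > 50000 nM in this assay, at which 2 of the 4 values shown sit. The series therefore offers one readable instance of the swap, which does not show whether it behaves alike on both cores.

The compounds shown leave open what an aromatic ring carrying an amine or a carboxylic acid would give in place of the hydroxyphenyl group. They also leave open whether any other core would give a readable step.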